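Removing the Ring Substituent: Predicting Compound 4

A few compounds are considered here, and "the series" means these few. Any claim that something is new, unique, unknown or untested is made for them only; others in the source may bear on it.

Three compounds have been measured in a functional assay for inhibition of nuclear factor NF-kappa-B complex (Homo sapiens); a lower number here means a stronger inhibitor, a higher number a weaker inhibitor:
Compound 1 `COc1ccc2c(c1)OC(c1cc(OC)c(OC)c(OC)c1)C(C(C)=O)=C2` gives 14100 nM.
Compound 2 `COc1ccc2c(c1)OC(c1cc(OC)c(OC)c(OC)c1)C(C(=O)OCCc1ccccc1)=C2` gives 16200 nM.
Compound 3 `COc1ccc2c(c1)OC(c1cc(OC)c(OC)c(OC)c1)C(/C=N/O)=C2` gives 14100 nM.

All three share the same core and differ only in the group attached to a double-bonded carbon of the six-membered non-aromatic ring that contains one oxygen. Compound 3 sits level with compound 1 at the digits shown, the two together being the lowest of the three numbers, and the remaining step is a 1.1-fold lower number from compound 2 to compound 3 (0.06 log units; within the scatter), so none of the three is separated from another beyond the scatter.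

Compound 4 `COc1ccc2c(c1)OC(c1cc(OC)c(OC)c(OC)c1)C=C2` removes this substituent altogether: a hydrogen atom in place of a group of 3 heavy atoms (1 carbon, 1 nitrogen, 1 oxygen; no ring), on a double-bonded ring carbon. The earlier steps shown here bear on this directly. Exchanging a methyl for phenethyloxy on the carbonyl carbon gave a 1.1-fold higher number from compound 1 to compound 2 (0.06 log units; within the scatter), and exchanging the whole group for the three-atom group of compound 3 gave no change at the digits printed from compound 1 to compound 3 (within the scatter). Going by the values given here, since small, large and nitrogen-containing groups at this position all produced the same number within the scatter, the position appears tolerant of change, though no measured step yet covers a bare hydrogen there. A step of a 1.0-fold lower number from compound 3 to compound 4 (0.00 log units; within the scatter) is therefore expected, with no shift beyond the scatter. Compound 4 is estimated at 14000 nM, ranging from 5000 nM to 40000 nM.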

Compound 4, half-maximal inhibitory concentration: 17700 nM
Beside the measured number, compound 4's estimate is 1.3-fold (0.10 log units) below it, within the range that was stated.
By their numbers in this assay, from the lowest: compounds 1, 3, 2 and 4 (each within the scatter of the next).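

In this assay, going by these compounds alone, compound 4 adds the one case the earlier compounds lacked at this double-bonded ring carbon, a bare hydrogen with no substituent at all: the result is a 1.3-fold higher number from compound 3 to compound 4 (0.10 log units; within the scatter), alongside a 1.3-fold higher number from compound 1 to compound 4 (0.10 log units; within the scatter) and a 1.1-fold higher number from compound 2 to compound 4 (0.04 log units; within the scatter). Within the data shown here, the earlier compounds showed only that one group could replace another here, whereas these steps show that acetyl, phenethyloxycarbonyl and the group of 3 heavy atoms in compound 3 can each be replaced by hydrogen with no shift beyond the scatter. Across these four compounds, then, the number cannot be traced to the group at this position, since having no group there gives a value within the scatter of the others.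

No supporting information is available here to explain this tolerance. Still open, on these data alone, is whether an amine, a carboxylic acid or a longer alkyl chain at this ring carbon would also stay within the scatter, and what changing the methoxy groups on the shared core would do to the number.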